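Two chlorines on a pyridyl ether: what to expect

The source may hold more compounds than are shown below. What is called first, only, known or untested is meant among the compounds shown, and "the series" means these compounds.

Compound 1 `O=C(O)c1ccc2noc(-c3cccc(-c4ccccc4)c3)c2c1`, compound 2 `O=C(O)c1ccc2noc(-c3cccc(Oc4ccccc4)c3)c2c1` and compound 3 `O=C(O)c1ccc2noc(-c3cccc(Oc4ccccn4)c3)c2c1` share one core and differ only in the group hanging from it. In an assay for inhibition of inositol hexakisphosphate kinase 3 (Homo sapiens), read by colorimetric assay, coupled enzyme assay and malachite green, with a stated time of 120 min, in the presence of a further agent that is not named here (on this read-out lower numbers stand for stronger inhibition and higher numbers for weaker inhibition), compound 1 gives 840 nM, compound 2 gives 850 nM and compound 3 gives 10900 nM, the highest of the three. The steps of a 13-fold higher number from compound 1 to compound 3 (1.11 log units; beyond the scatter) and a 13-fold higher number from compound 2 to compound 3 (1.11 log units; beyond the scatter) were both large, whereas a 1.0-fold higher number from compound 1 to compound 2 (0.01 log units; within the scatter) stayed within the scatter. Compound 4 `O=C(O)c1ccc2noc(-c3cccc(Oc4ncc(Cl)cc4Cl)c3)c2c1` carries 3,5-dichloropyridin-2-yl in place of pyridin-2-yl on an oxygen on an aromatic ring. Among the measured compounds shown here, no measured step involves chlorine, so this change is untested here; the nearest guide is that compound 3 sits far above compound 2, leaving room to move back down. Compound 4 is therefore expected to show a 2.2-fold lower number from compound 3 to compound 4 (0.34 log units; beyond the scatter) in this assay, downward if anything. The estimate for compound 4 is 5000 nM, with a range from 1200 nM to 20000 nM.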

Compound 4, half-maximal inhibitory concentration: 3090 nM
Beside the measured number, compound 4's estimate is 1.6-fold (0.21 log units) above it, and the stated range covers the measured number.
By their numbers in this assay, from the lowest: compounds 1 and 2 (each within the scatter of the next); then compound 4; then compound 3.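

In this assay, 3,5-dichloropyridin-2-yl in place of pyridin-2-yl on the oxygen gives a 3.5-fold lower number from compound 3 to compound 4 (0.55 log units; beyond the scatter) and so shows that this ring can be changed to regain some of the ground lost. The recovery is only partial, with a 3.6-fold higher number from compound 2 to compound 4 (0.56 log units; beyond the scatter) and a 3.7-fold higher number from compound 1 to compound 4 (0.57 log units; beyond the scatter) still separating the dichloro compound from the two compounds without a ring nitrogen. Nothing available here explains why the two chlorines make this difference.

As far as these compounds go, whether a single chlorine would do as much remains open. So does whether a methyl or methoxy group on the pyridin-2-yl ring would lower the number further.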